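Chloro on the Shared Core: Nitro Versus Amino Sulfonamides

The compounds below may be only part of what the source reports. "The series", "measured", "known", "first", "only" and "open" are said of these compounds alone.

Measured so far, in a functional assay on KB cells (Homo sapiens) for antiproliferative activity, read by colorimetric assay and MTT assay; on this read-out lower numbers stand for stronger inhibition and higher numbers for weaker inhibition: compound 1 `O=[N+]([O-])c1ccc(S(=O)(=O)Nc2cccc3cc[nH]c23)cc1` gives 15 ug/mL; compound 2 `O=[N+]([O-])c1ccc(S(=O)(=O)Nc2cccc3c(Cl)c[nH]c23)cc1` gives 14 ug/mL; compound 3 `Nc1ccc(S(=O)(=O)Nc2cccc3cc[nH]c23)cc1` gives 36 ug/mL.

Compound 2 differs from compound 1 by chloro in place of hydrogen on an aromatic carbon, and the step was a 1.1-fold lower number from compound 1 to compound 2 (0.03 log units; within the scatter). Compound 3 differs from compound 1 by amino in place of nitro on an aromatic carbon, and here the step was a 2.4-fold higher number from compound 1 to compound 3 (0.38 log units; beyond the scatter). Compound 4 `Nc1ccc(S(=O)(=O)Nc2cccc3cc(Cl)[nH]c23)cc1`, not yet measured, differs from compound 3 by chloro in place of hydrogen on an aromatic carbon. This is the same kind of change as that from compound 1 to compound 2, but not the same: there the chloro sat two ring bonds from the ring nitrogen, here it sits next to the ring nitrogen. Because a 1.1-fold lower number from compound 1 to compound 2 (0.03 log units; within the scatter), compound 4 is expected to sit close to compound 3, with an estimated step of a 1.1-fold lower number from compound 3 to compound 4 (0.05 log units; within the scatter). For compound 4 in this assay the estimate is 32 ug/mL, between 16 ug/mL and 64 ug/mL.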

Compound 4, half-maximal inhibitory concentration: 1.4 ug/mL
For compound 4 the middle estimate is 23-fold (1.36 log units) above the measured one; the whole stated range lies above it.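

In this assay, chloro in place of hydrogen next to the ring nitrogen on the core of compound 3 produced a large step (a 26-fold lower number from compound 3 to compound 4 (1.41 log units; beyond the scatter)). Set beside the earlier chloro step, this change did not carry from one core to the other at the same size: (the same change on two cores in this assay, a 1.1-fold lower number (0.03 log units; within the scatter) from compound 1 to compound 2 and a 26-fold lower number (1.41 log units; beyond the scatter) from compound 3 to compound 4, 24-fold (1.38 log units) apart, beyond the scatter of two such steps). This does not show what sets the two steps apart, as they differ both in amino versus nitro on the core and in where the chloro sits.

As far as these compounds go, it remains open how chloro next to the ring nitrogen would act on the nitro core of compound 1, and how chloro in its compound 2 place would act on the amino core. From the compounds shown here alone, whether bromo or methyl next to the ring nitrogen would match compound 4 is also open.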